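This account rests on a few compounds, and the source may have more. Where it says the series, first, only, none or still open, it means among the compounds named here.

Three compounds share one core, and in a functional assay on BXPC-3 cells (Homo sapiens) for inhibition, read by MTT assay, with a stated time of 7 days (on this read-out higher numbers stand for weaker inhibition and lower numbers for stronger inhibition), they spread over a wide span. Compound 1 `CCN(CC)S(=O)(=O)c1ccc(S(=O)(=O)N2CCC[C@@H](C(=O)N[C@H]3CC[C@H](OC)CC3)C2)cc1` gives 2000 nM in this assay. Compound 2 `O=C([C@@H]1CCCN(S(=O)(=O)c2ccc(S(=O)(=O)C3CCC3)cc2)C1)N1CCC(F)(F)CC1` gives 78 nM in this assay. Compound 3 `CCN(CC)S(=O)(=O)c1ccc(S(=O)(=O)N2CCC[C@@H](C(=O)N3CCC(OC)CC3)C2)cc1` gives 1420 nM in this assay, which places it second highest of the three numbers: its nearest neighbour is compound 1, and its furthest is compound 2, whose number is far lower. Among the compounds with values here, the only single-point step among the measured compounds, a 1.4-fold lower number from compound 1 to compound 3 (0.15 log units; within the scatter), lies within the scatter, so replacing the open amide with the closed ring at the carbonyl made no discernible difference.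

Compound 4 `CCN(CC)S(=O)(=O)c1ccc(S(=O)(=O)N2CCC[C@@H](C(=O)N3CCOCC3)C2)cc1` continues from compound 3 with morpholin-4-yl in place of 4-methoxypiperidin-1-yl on a carbonyl carbon. Within the data shown here, no measured step bears directly on this change; the one step that touches the same carbonyl position left the number essentially where it was. Compound 4 is therefore expected to stay near compound 3, with a step of about a 1.4-fold higher number from compound 3 to compound 4 (0.15 log units; within the scatter) and no movement beyond the scatter. The expected value for compound 4 in this assay is 2000 nM, with a range from 700 nM to 6000 nM.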

Compound 4, half-maximal inhibitory concentration: 790 nM
Beside the measured number, compound 4's estimate is 2.5-fold (0.40 log units) above it; measured number inside the range.
By their numbers in this assay, from the lowest: compound 2; then compounds 4, 3 and 1 (each within the scatter of the next, the first and the last beyond it).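

In this assay, the exchange of 4-methoxypiperidin-1-yl for morpholin-4-yl on the carbonyl carbon gives a 1.8-fold lower number from compound 3 to compound 4 (0.25 log units; within the scatter), so a second ring change at this position also leaves the number unresolved from its predecessor. Set against the (4-methoxycyclohexyl)amino group, however, morpholin-4-yl gives a 2.5-fold lower number from compound 1 to compound 4 (0.40 log units; beyond the scatter), a modest step and the only one at this position that lies beyond the scatter. Nothing available explains this step.

Compound 2 differs from the others in more than one place, so the compounds shown do not tell how much of its far lower number belongs to the group on the carbonyl carbon. Also open, going by these compounds, is how the number would respond if a piperazin-1-yl group or a chain ending in a carboxylic acid stood on that carbonyl carbon.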